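The source may report more compounds than this note shows. Statements on the series, on what has been measured and on what is new or still open speak of the compounds shown alone.

Measured so far in a functional assay on HT-29 cells (Homo sapiens) for inhibition, read by MTT assay, with a stated time of 120 h; on this read-out lower numbers stand for stronger inhibition and higher numbers for weaker inhibition:
- compound 1, `CC(NC(=O)/C=C/Oc1ccc(NC(=O)Nc2cc(C(F)(F)F)ccc2Cl)cc1)c1ccccc1`: > 50000 nM, which is a limit of the assay and not a number
- compound 2, `CNC(=O)C#Cc1ccc(NC(=O)Nc2ccc(Cl)c(C(F)(F)F)c2)cc1`: 14000 nM
- compound 3, `CC(NC(=O)c1cccc(-c2ccc(NC(=O)Nc3ccc(Cl)c(C(F)(F)F)c3)cc2)c1)c1ccccc1`: 6320 nM

Of the two compounds that gave a number in this assay, compound 2 stands at the higher one, meaning the weaker inhibition. The nearest neighbour is compound 3, whose number is lower by a step that lies beyond the usual scatter of repeated measurements. Compound 1 sits at the limit of this assay, as the line the limit of > 50000 nM in this assay, at which 1 of the 3 values shown sits, records, so it contributes no number to compare.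

The compound still to be measured is compound 4, `CNC(=O)/C(C)=C/c1ccc(NC(=O)Nc2ccc(Cl)c(C(F)(F)F)c2)cc1`. It differs from compound 2 in one place: 2-(methylcarbamoyl)prop-1-en-1-yl in place of 2-(methylcarbamoyl)ethynyl on an aromatic carbon. The shared core with its urea and its chloro- and trifluoromethyl-bearing ring stays the same, so the whole comparison rests on swapping the ethynyl linker for the prop-1-en-1-yl one.

Going by the values given here, since no pair of measured compounds shows this kind of change, the step from compound 2 to compound 4 in this assay is expected to be small, most likely within the scatter, and is estimated as a 1.4-fold lower number from compound 2 to compound 4 (0.15 log units; within the scatter). Compound 4 is therefore expected to give about 10000 nM in this assay, within a range from 2500 nM to 40000 nM.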

Compound 4, half-maximal inhibitory concentration: > 50000 nM
Compound 4: a limit, no number; the forecaster's own chance of this, stated with the estimate: 10%; middle value at least 5.0-fold (0.69 log units) away from the limit.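

Going by these compounds alone, until now, no pair of compounds in this assay showed what a change at this place does. Replacing 2-(methylcarbamoyl)ethynyl with 2-(methylcarbamoyl)prop-1-en-1-yl, on an aromatic carbon para to a large group, gives an at least 3.5-fold higher number from compound 2 to compound 4 (0.55 log units; beyond the scatter), so inhibition in these cells depends on which of these two side chains sits here, even though the rest of the molecule stays the same. The real size of this step remains unknown because compound 4 gave a limit and not a number: the limit of > 50000 nM in this assay, at which 2 of the 4 values shown sit.

The change swaps a triple bond for a double bond and also adds a methyl group, and the compounds shown cannot tell which of these two differences matters, or whether both do. Going by these compounds, it also remains open whether a plain 2-(methylcarbamoyl)ethenyl side chain, without the methyl group, would stay measurable, and whether an amine or a carboxylic acid at the end of the side chain would give a lower number than the methyl amide does.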